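The source may hold more compounds than are shown below. What is called first, only, known or untested is meant among the compounds shown, and "the series" means these compounds.

Measured compounds in an in vitro assay on HEK-tsA201 cells for antagonist activity at Neuronal acetylcholine receptor; alpha3/beta4 (Homo sapiens), read by fluorescence and calcium flux; on this read-out higher numbers stand for weaker inhibition and lower numbers for stronger inhibition:

- compound 1, `CCCNc1cccc(NC(=O)c2ccc(OCCC)cc2)n1`: 12600 nM
- compound 2, `CCCCNc1cccc(NC(=O)c2ccc(OCCC)cc2)n1`: 77800 nM
- compound 3, `C=CCOc1ccc(C(=O)Nc2cccc(NCCC)n2)cc1`: 11700 nM

Compound 1 and compound 3 share a core and differ only in that (vinyl in place of ethyl on a saturated chain carbon bound to an oxygen on an aromatic ring). The step of a 1.1-fold lower number from compound 1 to compound 3 (0.03 log units; within the scatter), so compound 1 and compound 3 are treated as equivalent in this assay; no order is read between them.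

Going by the values given here, the one change with a measured effect is that from compound 1 to compound 2: methyl in place of hydrogen on a saturated chain carbon, three bonds along the chain from a nitrogen on an aromatic ring. Here a 6.2-fold higher number from compound 1 to compound 2 (0.79 log units; beyond the scatter), and compound 2 stands furthest from compound 3 among the measured set.

Compound 4, `C=CCOc1ccc(C(=O)Nc2cccc(NCCCC)n2)cc1`, is not yet measured. It differs from compound 3 in that (methyl in place of hydrogen on a saturated chain carbon, three bonds along the chain from a nitrogen on an aromatic ring). The place of the change is worded identically for the pair compound 1 to compound 2 and for the pair compound 3 to compound 4, so this is the same change made on the core of compound 3 instead of the core of compound 1. Since the cores behave alike, as shown by a 1.1-fold lower number from compound 1 to compound 3 (0.03 log units; within the scatter), the expectation is that the step repeats: a 6.0-fold higher number from compound 3 to compound 4 (0.78 log units; beyond the scatter) is expected, resting on a 6.2-fold higher number from compound 1 to compound 2 (0.79 log units; beyond the scatter). That yields an estimated value for compound 4 of 70000 nM, with an expected range from 25000 nM to 200000 nM. Because compound 3 already gives 11700 nM, a weak number on this read-out, the expected value for compound 4 lies at the weak end of what has been measured so far.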

Compound 4, half-maximal inhibitory concentration: 19200 nM
Compound 4: the middle estimate sits 3.6-fold (0.56 log units) above what was measured; the measured number lies below the stated range.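

In this assay, methyl in place of hydrogen on a saturated chain carbon, three bonds along the chain from a nitrogen on an aromatic ring, gives a 1.6-fold higher number from compound 3 to compound 4 (0.22 log units; within the scatter), so the change does not carry over from the core of compound 1 to the core of compound 3 at the size first seen: the same change on two cores in this assay, a 6.2-fold higher number (0.79 log units; beyond the scatter) from compound 1 to compound 2 and a 1.6-fold higher number (0.22 log units; within the scatter) from compound 3 to compound 4, 3.8-fold (0.58 log units) apart, beyond the scatter of two such steps

The same four compounds read the other way show vinyl in place of ethyl, on a saturated chain carbon bound to an oxygen on an aromatic ring, giving a 4.1-fold lower number from compound 2 to compound 4 (0.61 log units; beyond the scatter), so this change also depends on the core that carries it: the same change on two cores in this assay, a 1.1-fold lower number (0.03 log units; within the scatter) from compound 1 to compound 3 and a 4.1-fold lower number (0.61 log units; beyond the scatter) from compound 2 to compound 4, 3.8-fold (0.58 log units) apart, beyond the scatter of two such steps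

Both gaps come from one set of four compounds, so they show that the two changes are not additive here, but they do not show why, nor whether this holds for any other pair of groups.

Open, as far as these compounds go, is whether a longer chain such as pentyl, three bonds or more along from the nitrogen, keeps the two cores apart or brings them together. Also open, from the compounds shown here alone, is whether an amine or a hydroxyl at the end of that chain follows the same pattern on either core.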